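Aryl amide substituent change in the nitrobenzofurazan ester series

The source may report more compounds than this note shows. Statements on the series, on what has been measured and on what is new or still open speak of the compounds shown alone.

Two members of this series carry a measured number in an assay on isolated protein for inhibition of glutathione S-transferase Mu 2 (Homo sapiens), with a stated time of 10 min; a higher number here means a weaker inhibitor, a lower number a stronger inhibitor. Compound 1 `O=C(CCC(=O)OCCCCCCSc1ccc([N+](=O)[O-])c2nonc12)Nc1ccccc1F` gives 350 nM in this assay. Going by the values given here, compound 2 `COc1ccccc1NC(=O)CCC(=O)OCCCCCCSc1ccc([N+](=O)[O-])c2nonc12` gives 280 nM in this assay, and a 1.3-fold lower number from compound 1 to compound 2 (0.10 log units; within the scatter) marks the only measured step so far: methoxy in place of fluoro on an aromatic carbon. Compound 2 has the lowest of the two numbers, but its step to compound 1 lies within the scatter, so no order between them can be read.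

Compound 3 `O=C(CCC(=O)OCCCCCCSc1ccc([N+](=O)[O-])c2nonc12)Nc1cccc(Cl)c1` is not yet measured. It differs from compound 2 in 3-chlorophenyl in place of 2-methoxyphenyl on an amide-type nitrogen, leaving the shared core untouched. Among the compounds with values here, the one measured step, from compound 1 to compound 2, also swaps a substituent on the phenyl amide, and it stayed within the scatter. Within the data shown here, since the only comparable change in this set gave no movement beyond the scatter, the expected step of a 1.3-fold higher number from compound 2 to compound 3 (0.10 log units; within the scatter) for compound 3 is likewise none beyond the scatter. The estimate for compound 3 in this assay is 350 nM, with a range from 150 nM to 800 nM.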

Compound 3, half-maximal inhibitory concentration: 1100 nM
Compound 3: the middle estimate sits 3.1-fold (0.50 log units) below what was measured; measured number outside the range, above it.
By their numbers in this assay, from the lowest: compounds 2 and 1 (each within the scatter of the next); then compound 3.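

At the aryl group on the amide-type nitrogen, the number in this assay can move beyond the scatter, which the earlier swap of methoxy for fluoro on the aromatic carbon did not show. Both new steps are modest: 3-chlorophenyl in place of 2-methoxyphenyl gives a 3.9-fold higher number from compound 2 to compound 3 (0.59 log units; beyond the scatter), and 3-chlorophenyl in place of 2-fluorophenyl gives a 3.1-fold higher number from compound 1 to compound 3 (0.50 log units; beyond the scatter). Both steps change the substituent and its numbered place on the phenyl ring at once, so these compounds cannot show which of the two matters, and no measurement at hand accounts for either step.

Still open, as far as these compounds go, is how 2-chlorophenyl and 3-methoxyphenyl on the same amide-type nitrogen would compare, since that pair would separate the identity of the substituent from its numbered place on the ring. Also open is where an unsubstituted phenyl, or a phenyl carrying an amine or a carboxylic acid, would fall in this assay relative to the three compounds shown, and whether the shared core would keep the same order with such groups.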